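From 3-nitrophenyl to 4-methoxyphenyl on the shared core

The source may hold more compounds than are shown below. What is called first, only, known or untested is meant among the compounds shown, and "the series" means these compounds.

In a functional assay on MCF7 cells (Homo sapiens) for cytotoxicity, read by MTT assay, with a stated time of 96 h (on this read-out higher numbers stand for weaker inhibition and lower numbers for stronger inhibition), compound 1 (`COc1cc(C(=O)c2cn(-c3ccccc3)cc2-c2ccc(N)cc2)cc(OC)c1OC`) gives 9 nM, compound 2 (`COc1cc(C(=O)c2cn(-c3ccccc3)cc2-c2ccc(Br)cc2)cc(OC)c1OC`) gives 340 nM and compound 3 (`COc1cc(C(=O)c2cn(-c3ccccc3)cc2-c2cccc([N+](=O)[O-])c2)cc(OC)c1OC`) gives 50 nM. Compound 3 thus holds the second highest of the three numbers. Compound 4 (`COc1ccc(-c2cn(-c3ccccc3)cc2C(=O)c2cc(OC)c(OC)c(OC)c2)cc1`) carries 4-methoxyphenyl in place of 3-nitrophenyl on an aromatic carbon of the five-membered aromatic ring: 4-methoxyphenyl in place of 3-nitrophenyl on an aromatic carbon.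

Going by the values given here, three measured steps concern this same place. Bromo in place of amino is large, at a 38-fold higher number from compound 1 to compound 2 (1.58 log units; beyond the scatter). The two steps that reach the 3-nitrophenyl group are modest and run in opposite directions: from 4-aminophenyl, a 5.6-fold higher number from compound 1 to compound 3 (0.74 log units; beyond the scatter), and from 4-bromophenyl, a 6.8-fold lower number from compound 2 to compound 3 (0.83 log units; beyond the scatter). Among the compounds with values here, no measured compound carries a methoxy group here, so the data fix no direction for the new group. No step beyond the scatter is therefore expected in this assay. The estimated step is a 1.3-fold lower number from compound 3 to compound 4 (0.10 log units; within the scatter). Compound 4 is expected at 40 nM, with an estimated range of 10 nM to 200 nM.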

Compound 4, half-maximal inhibitory concentration: 70 nM
Compound 4: middle estimate off by 1.8-fold (0.24 log units), on the low side; low and high end bracket the measured number.
By their numbers in this assay, from the lowest: compound 1; then compounds 3 and 4 (each within the scatter of the next); then compound 2.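

In this assay, 4-methoxyphenyl in place of 3-nitrophenyl stays within the scatter, with a 1.4-fold higher number from compound 3 to compound 4 (0.15 log units; within the scatter). Methoxy in place of bromo gives a 4.9-fold lower number from compound 2 to compound 4 (0.69 log units; beyond the scatter), and methoxy in place of amino gives a 7.8-fold higher number from compound 1 to compound 4 (0.89 log units; beyond the scatter). At this place on the five-membered aromatic ring, amino therefore remains alone at the low end and bromo alone at the high end, while the 4-methoxyphenyl and 3-nitrophenyl groups cannot be told apart between them.

No evidence is at hand that accounts for these differences. On these data alone, it remains open whether a hydroxyl or a dimethylamino group in place of amino would keep a number near that of compound 1 at 9 nM, and how a 4-nitrophenyl group would compare with the 3-nitrophenyl group.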